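Alkyne to Alkene on the Amide of Compound 2

The compounds below may be only part of what the source reports. "The series", "measured", "known", "first", "only" and "open" are said of these compounds alone.

Of the compounds shown here, two have been measured in a functional assay on NIH3T3 cells for agonist activity at Urotensin-2 receptor (Homo sapiens), with a stated time of 5 days; on this read-out higher numbers stand for larger maximal responses and lower numbers for smaller maximal responses. Compound 1 `Cc1ccc(C(CCN(C)C)NC(=O)C#Cc2ccccc2)cc1` reaches 131% in this assay. Compound 2 `CN(C)CCC(NC(=O)C#Cc1ccccc1)c1ccc(Cl)cc1` reaches 124% in this assay. Going by the values given here, the single step that links them, chloro in place of methyl on an aromatic carbon, gives a number 7 percentage points lower from compound 1 to compound 2 (within the scatter), so on the two numbers at hand compound 2 stands alongside compound 1 with nothing between them beyond the scatter.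

Compound 3 `CN(C)CCC(NC(=O)/C=C/c1ccccc1)c1ccc(Cl)cc1` has not yet been measured in this assay. It differs from compound 2 in one place: 2-phenylethenyl in place of 2-phenylethynyl on a carbonyl carbon. Among the compounds with values here, no measured step concerns this change; the only step recorded, the one from compound 1 to compound 2, alters the aromatic substituent and leaves the 2-phenylethynyl group untouched, so it offers no guide to swapping that group for 2-phenylethenyl. With nothing in the data pointing either way, the expectation for compound 3 is that it stays close to compound 2, with a step of a number 9 percentage points lower from compound 2 to compound 3 (within the scatter) in this assay. Compound 3 is therefore estimated at 115%, in a range from 85% to 140%.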

Compound 3, largest response reached (reported as efficacy), in percent of the reference or control that the assay uses: 128%
Compound 3: the middle estimate sits 13 percentage points below what was measured; the range from low to high includes it.
By their numbers in this assay, from the lowest: compounds 2, 3 and 1 (each within the scatter of the next).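

Taking 2-phenylethenyl in place of 2-phenylethynyl on a carbonyl carbon gives a number 4 percentage points higher from compound 2 to compound 3 (within the scatter) in this assay and so provides the first reading at this position, since the earlier step from compound 1 to compound 2 concerned only the aromatic substituent. For this pair, the triple bond outside aromatic rings is not needed to keep the response: compound 3, with a double bond in its place, reads alike within the scatter, and the two groups match in heavy atoms and aromatic ring, differing only in that bond. Nothing given here bears on why the two groups read alike.

From the compounds shown here alone, what stays open is whether the response would hold with 2-phenylethyl, which has neither a double nor a triple bond in its chain, or with a pyridine ring in place of the phenyl ring of the group on the carbonyl carbon. The compounds shown also leave open whether 2-phenylethenyl would read the same alongside the methyl group of compound 1, and whether a piperidine could take the place of the dimethylamino group.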